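From Compound 2 to Compound 3: A Carbonyl Enters

The source may report more compounds than this note shows. Statements on the series, on what has been measured and on what is new or still open speak of the compounds shown alone.

Of the compounds shown here, two sharing one core have been measured so far in a functional assay on HepG2 cells (Homo sapiens) for inhibition, read by MTT assay, with a stated time of 48 h; a higher number here means a weaker inhibitor, a lower number a stronger inhibitor. Compound 1 `COc1ccc(-n2c(SCc3ccccc3)nnc2-c2cc(OC)c(OC)c(OC)c2)cc1` gives > 60000 nM, which is a limit of the assay and not a number. Going by the values given here, compound 2 `COc1ccc(-n2c(SCc3ccc(F)cc3)nnc2-c2cc(OC)c(OC)c(OC)c2)cc1` gives 35000 nM, the only actual number so far, so it has no measured number to stand against.

Compound 3 `COc1ccc(-n2c(SCC(=O)c3ccc(F)cc3)nnc2-c2cc(OC)c(OC)c(OC)c2)cc1` carries (4-fluorophenyl)carbonyl in place of 4-fluorophenyl on a saturated chain carbon bound to a sulfur. Among the compounds with values here, only one measured step is available, and it bears on this change only loosely: fluoro in place of hydrogen on an aromatic carbon gave an at least 1.7-fold lower number from compound 1 to compound 2 (0.23 log units; that floor lies within the scatter). That is a different change, and it offers no measured size for the new one. With this single step as the guide, no move beyond the scatter is expected in this assay, and no direction can be firmly expected. The expected step is a 1.3-fold lower number from compound 2 to compound 3 (0.10 log units; within the scatter). For compound 3 the estimated value is 28000 nM. The expected range for compound 3 runs from 9000 nM to 60000 nM.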

Compound 3, half-maximal inhibitory concentration: 10700 nM
Compound 3: the middle estimate sits 2.6-fold (0.42 log units) above what was measured, and the stated range covers the measured number.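

In this assay, going by these compounds alone, the group on this saturated chain carbon bound to a sulfur now gives the first step that clearly lies beyond the scatter: (4-fluorophenyl)carbonyl in place of 4-fluorophenyl gives a 3.3-fold lower number from compound 2 to compound 3 (0.51 log units; beyond the scatter). Within the data shown here, the only earlier step, fluoro in place of hydrogen on an aromatic carbon, had a floor within the scatter, whereas this change shows that the number can respond to a change at this position, with the entering group bringing a carbonyl and its one hydrogen-bond acceptor. Read from the phenyl compound, the change gives an at least 5.6-fold lower number from compound 1 to compound 3 (0.74 log units; beyond the scatter), a size that is only a floor, since compound 1 stands at a limit of the assay and not at a number: the limit of > 60000 nM in this assay, at which 1 of the 3 values shown sits.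

On these data alone, it remains open whether the step belongs to the carbonyl itself, and whether a hydroxyl in its place or a longer chain would give a step of similar size. Also open, as far as these compounds go, is whether the fluoro still matters alongside the carbonyl, and whether an amine or a carboxylic acid in place of that fluoro would lower the number further.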